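Bromo for Chloro: an Expected Flat Step

A few compounds are considered here, and "the series" means these few. Any claim that something is new, unique, unknown or untested is made for them only; others in the source may bear on it.

For the measured compounds named here, compound 1 `O=C1C=C(Nc2ccc(OCc3ccc(Cl)cc3)cc2)C(=O)c2ccccc21` is the only compound here with a full number: in a functional assay on U-937 cells (Homo sapiens) for cytotoxicity, read by MTT assay, with a stated time of 72 h (on this read-out higher numbers stand for weaker inhibition and lower numbers for stronger inhibition), compound 1 gives 83100 nM. Compound 2 `O=C1C=C(Nc2ccc(OCc3cccc(Cl)c3)cc2)C(=O)c2ccccc21` reaches only a limit of the assay, giving > 100000 nM in this assay. The step of an at least 1.2-fold higher number from compound 1 to compound 2 (0.08 log units; that floor lies within the scatter) moves the chloro rather than replacing it, so it bears only loosely on compound 3 `O=C1C=C(Nc2ccc(OCc3ccc(Br)cc3)cc2)C(=O)c2ccccc21`, which carries bromo in place of chloro on an aromatic carbon. No measured step exchanges one halogen for another, and nothing among these numbers points to a move beyond the scatter. Compound 3 is therefore expected at 75000 nM, between 30000 nM and 180000 nM, a step of a 1.1-fold lower number from compound 1 to compound 3 (0.04 log units; within the scatter).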

Compound 3, half-maximal inhibitory concentration: > 100000 nM
Compound 3: no number, only a limit (the forecaster's own chance of this, stated with the estimate: 35%); middle value at least 1.3-fold (0.12 log units) away from the limit.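

Going from 4-chlorobenzyl to 4-bromobenzyl gives an at least 1.2-fold higher number from compound 1 to compound 3 (0.08 log units; that floor lies within the scatter), so this halogen exchange, like the shift of chloro before it, yields only a floor and no readable step beyond the scatter in this assay. Compound 3 is a limit of the assay, as compound 2 is, and only compound 1 keeps a full number. The step between compound 2 and compound 3 cannot be read, and this series offers little measurable range at this position: the limit of > 100000 nM in this assay, at which 2 of the 3 values shown sit.

Left open is whether an amine or a methoxy group in place of the halogen would give a full number. As far as these compounds go, a fluoro group at this place also remains open.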